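Aryl ketone variation in a hydroxamate series

The source may hold more compounds than are shown below. What is called first, only, known or untested is meant among the compounds shown, and "the series" means these compounds.

The compounds share one core carrying a hydroxamate arm and an enone bearing an aryl ketone. Compound 1 `Cn1cc(/C=C/C(=O)c2ccc(F)cc2)cc1/C=C/C(=O)NO` gives 24900 nM in an assay on isolated protein for inhibition of histone deacetylase HD1B (Zea mays) (on this read-out lower numbers stand for stronger inhibition and higher numbers for weaker inhibition), the second highest of the three numbers shown. Compound 2 `Cn1cc(/C=C/C(=O)c2ccc(-c3ccccc3)cc2)cc1/C=C/C(=O)NO` gives 31800 nM in this assay, and the step of a 1.3-fold higher number from compound 1 to compound 2 (0.11 log units; within the scatter) is within the scatter. For the measured compounds named here, compound 3 `CC/C(=C\c1cc(/C=C/C(=O)NO)n(C)c1)C(=O)c1ccccc1` differs from compound 1 in more than one place, so no single step is drawn for that pair; in this assay compound 3 gives 4500 nM, a lower number than compound 1.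

Compound 4 `Cn1cc(/C=C/C(=O)c2cccs2)cc1/C=C/C(=O)NO` is not yet measured. It differs from compound 1 by thiophen-2-yl in place of 4-fluorophenyl on a carbonyl carbon. Going by the values given here, the only measured step at the aryl ketone, from compound 1 to compound 2, changes the number by an amount within the scatter, and no measured pair exchanges the whole aryl group for a five-membered aromatic ring with one hetero atom. On that basis the step from compound 1 to compound 4 is expected to be small, a 1.2-fold lower number from compound 1 to compound 4 (0.10 log units; within the scatter), with no direction beyond the scatter claimed. Compound 4 is therefore estimated at 20000 nM in this assay, between 6000 nM and 60000 nM.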

Compound 4, half-maximal inhibitory concentration: 25800 nM
Compound 4: middle estimate off by 1.3-fold (0.11 log units), on the low side; low and high end bracket the measured number.
By their numbers in this assay, from the lowest: compound 3; then compounds 1, 4 and 2 (each within the scatter of the next).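

Thiophen-2-yl in place of 4-fluorophenyl on a carbonyl carbon gives a 1.0-fold higher number from compound 1 to compound 4 (0.02 log units; within the scatter) in this assay, so exchanging the whole aryl group at this position, and not only a group on the ring, also gives a step that stays within the scatter. This exchange goes from a six-membered aromatic ring of carbon only to a five-membered aromatic ring with 1 hetero atom, from 7 heavy atoms to 5, and from 0 hydrogen-bond acceptors to 1, and none of these differences appears as a step beyond the scatter on this read-out. No measured information bears on why this step stays within the scatter.

As far as these compounds go, it remains open whether a group of another kind on the ketone, such as an amine, a carboxylic acid or an open alkyl chain in place of the ring, would give a step beyond the scatter from compound 1. Compound 3 has no partner differing in one place among the compounds shown, so its 4500 nM cannot be assigned to any single change.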